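A few compounds are considered here, and "the series" means these few. Any claim that something is new, unique, unknown or untested is made for them only; others in the source may bear on it.

Working notes on the series, read in a physicochemical assay for solubility, measured as kinetic solubility; on this read-out lower numbers stand for lower solubility and higher numbers for higher solubility. Compound 1 `Cc1cc(C)c(CN2CCc3c(Cl)cc([C@@H](CO)[C@@H]4CCOC4)c(Cl)c3C2=O)c(=O)[nH]1` gives 537000 nM; this is the only number shown for it, alongside one further entry that carries no single value. Compound 2 `COC(c1cc(Cl)c2c(c1Cl)C(=O)N(Cc1c(C)cc(C)[nH]c1=O)CC2)C1CCN(C(C)=O)CC1` gives 532000 nM; 498000 nM (2 entries), and its repeated entries the several entries of compound 2 in this assay, 532000 nM; 498000 nM (2 entries) sit close together, so the two measured compounds stand at much the same level in this assay. Compound 3 `Cc1cc(C)c(CN2CCc3c(Cl)cc(-c4c(C)noc4C)c(Cl)c3C2=O)c(=O)[nH]1` is not yet measured. It differs from compound 1 by a group of 7 heavy atoms (5 carbon, 1 nitrogen, 1 oxygen; one five-membered aromatic ring with 2 hetero atoms) in place of a group of 8 heavy atoms (6 carbon, 2 oxygen; one five-membered non-aromatic ring with 1 hetero atom), on an aromatic carbon. Among the compounds with values here, no step between measured compounds is available to set the size of such a change, so the expectation rests on the structures alone: a step downward in this assay is expected for compound 3, somewhat beyond the usual scatter but not a large one. The estimate for compound 3 is 180000 nM, with a range from 60000 nM to 450000 nM. The expected step is a 3.0-fold lower number from compound 1 to compound 3 (0.47 log units; beyond the scatter).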

Compound 3, solubility: 93000 nM
For compound 3 the middle estimate is 1.9-fold (0.29 log units) above the measured one; the measured number falls inside the stated range.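

At this aromatic carbon, ortho to a chloro group, replacing the group in compound 1 with 3,5-dimethyl-1,2-oxazol-4-yl gives a clear change in this assay: a 5.8-fold lower number from compound 1 to compound 3 (0.76 log units; beyond the scatter). The entering group brings an aromatic ring to this position, with 0 hydrogen-bond donors and no defined stereocentre, whereas the leaving group has 1 hydrogen-bond donor and 2 defined stereocentres. The step is well outside the spread of repeat entries in this series: the several entries of compound 2 in this assay, 532000 nM; 498000 nM (2 entries)

This single step changes the ring, the donor count and the stereocentres together, so the compounds shown cannot say which of these goes with the lower number. On these data alone, how a carboxylic acid or an amine at this aromatic carbon would read in this assay also remains open.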